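From Iodo to Bromo: What to Expect for Compound 4

A few compounds are considered here, and "the series" means these few. Any claim that something is new, unique, unknown or untested is made for them only; others in the source may bear on it.

Three measured compounds share one core: compound 1 `CCOc1ccc(C(=O)/C=C/c2ccccc2)c(O)c1`, compound 2 `CC(=O)Oc1ccc(C(=O)/C=C/c2ccccc2)c(O)c1` and compound 3 `COc1ccc(C(=O)/C=C/c2ccccc2)c(O)c1I`. In a functional assay on Ca-Ski cells (Homo sapiens) for antiproliferative activity, with a stated time of 48 h (a higher number here means a weaker inhibitor, a lower number a stronger inhibitor), compound 1 gives "not determined" (no result reported), meaning no result was reported for it. Compound 2 reaches only a limit of this assay, > 50000 nM. Compound 3 likewise shows only a limit, > 50000 nM. So compound 3 stands at the edge of what this assay can report, with no single number known; this is the limit of > 50000 nM in this assay, at which 2 of the 3 values shown sit. Compound 4 `COc1ccc(C(=O)/C=C/c2ccccc2)c(O)c1Br` differs from compound 3 by bromo in place of iodo on an aromatic carbon. Among the compounds with values here, no step between two measured compounds exists to guide the size. Compound 4 is expected to stay near that limit, with the step of a number no higher from compound 3 to compound 4 (the limit leaves the size open) expected to be none beyond the scatter. Compound 4 is therefore estimated at 50000 nM, within 15000 nM to 150000 nM.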

Compound 4, half-maximal inhibitory concentration: > 50000 nM
Compound 4: no number, only a limit; the forecaster's own chance of this, stated with the estimate: 75%; the middle value sits exactly at the limit.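

Within the data shown here, compound 3 and compound 4 both give only a limit in this assay, and no step between them can be read. The compounds shown leave open how iodo and bromo compare on the shared core, and what single number either compound would reach.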